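Cyclohexyl in Place of Thiophen-2-yl: an Expectation

The compounds below may be only part of what the source reports. "The series", "measured", "known", "first", "only" and "open" are said of these compounds alone.

Of the compounds shown here, three built on one shared core have been measured in an assay on isolated protein for inhibition of proto-oncogene tyrosine-protein kinase receptor Ret (Homo sapiens), read by radiometric assay and 33P incorporation, in the presence of a further agent that is not named here; on this read-out lower numbers stand for stronger inhibition and higher numbers for weaker inhibition. Compound 1 `CC(C)n1nc(-c2cc(-c3ccccc3)on2)c(C(N)=O)c1N` carries a phenyl group and gives 236 nM. Compound 2 `CC(C)n1nc(-c2cc(-c3cccnc3)on2)c(C(N)=O)c1N` carries pyridin-3-yl and gives 3400 nM. Compound 3 `CC(C)n1nc(-c2cc(-c3cccs3)on2)c(C(N)=O)c1N` carries thiophen-2-yl and gives 78 nM, the lowest number of the three: a 3.0-fold lower number from compound 1 to compound 3 (0.48 log units; beyond the scatter) and a 44-fold lower number from compound 2 to compound 3 (1.64 log units; beyond the scatter), both beyond the scatter.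

Compound 4 `CC(C)n1nc(-c2cc(C3CCCCC3)on2)c(C(N)=O)c1N` has not yet been measured. It differs from compound 3 in one place: cyclohexyl in place of thiophen-2-yl on an aromatic carbon. For the measured compounds named here, no measured step exchanges an aromatic ring for a non-aromatic one at this place, so none bears on it directly. The three steps do show how strongly this position responds to a change of group: a 14-fold higher number from compound 1 to compound 2 (1.16 log units; beyond the scatter), a 3.0-fold lower number from compound 1 to compound 3 (0.48 log units; beyond the scatter) and a 44-fold lower number from compound 2 to compound 3 (1.64 log units; beyond the scatter). Given that all three exchanges moved the number beyond the scatter, and that the best number belongs to compound 3, the expectation for compound 4 is a higher number than compound 3 in this assay, by a modest to large step, a 5.1-fold higher number from compound 3 to compound 4 (0.71 log units; beyond the scatter). Compound 4 is therefore estimated at 400 nM, with a wide range from 80 nM to 2500 nM.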

Compound 4, half-maximal inhibitory concentration: 2700 nM
The estimate for compound 4 lay 6.8-fold (0.83 log units) below the measured number; the whole stated range lies below it.
By their numbers in this assay, from the lowest: compound 3; then compound 1; then compounds 4 and 2 (each within the scatter of the next).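

Replacing thiophen-2-yl with cyclohexyl gives a 35-fold higher number from compound 3 to compound 4 (1.54 log units; beyond the scatter) in this assay, and replacing phenyl with cyclohexyl gives an 11-fold higher number from compound 1 to compound 4 (1.06 log units; beyond the scatter), so at this place a non-aromatic ring of carbon only gives a clearly higher number than either of these two aromatic rings. Replacing pyridin-3-yl with cyclohexyl gives a 1.3-fold lower number from compound 2 to compound 4 (0.10 log units; within the scatter), so these two very different rings cannot be told apart here, and a number in this range is not tied to either an aromatic or a non-aromatic ring. No measurement at hand offers an explanation for this result.

The compounds shown leave open whether a smaller carbon ring such as cyclopentyl, or an open chain such as n-butyl, would stay with cyclohexyl or come closer to thiophen-2-yl. They also leave open whether a non-aromatic ring carrying an amine, such as piperidine, or a ring carrying a carboxylic acid would change the number at this place, and whether furan-2-yl would match thiophen-2-yl.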